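Pyrrole to a fused bicycle: an expected small step

The source may hold more compounds than are shown below. What is called first, only, known or untested is meant among the compounds shown, and "the series" means these compounds.

Among the compounds with values here, compound 2 `CCOC(=O)C1=C(Nc2ccccc2)S/C(=C\c2ccc[nH]2)C1=O` is one of only two compounds measured in a functional assay on MCF7 cells (Homo sapiens) for inhibition, read by MTT assay, with a stated time of 72 h, tested at 10 uM; on this read-out lower numbers stand for less inhibition and higher numbers for more inhibition at the one concentration tested (going by the name of the read-out). There compound 2 gives 18.3%, the lower of the two numbers, while its nearest neighbour, compound 1 `CCOC(=O)C1=C(Nc2ccccc2)S/C(=C\c2ccccc2)C1=O`, gives 23.6%; the two values are within the scatter of each other. Within the data shown here, the single measured step, a number 5.3 percentage points lower from compound 1 to compound 2 (within the scatter), exchanges one aromatic group for another at the same place and does not rise beyond the scatter.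

Compound 3 `CCOC(=O)C1=C(Nc2ccccc2)S/C(=C\c2cc3ccncc3[nH]2)C1=O` differs from compound 2 by a group of 9 heavy atoms (7 carbon, 2 nitrogen; one five-membered aromatic ring with 1 hetero atom, one six-membered aromatic ring with 1 hetero atom) in place of a group of 5 heavy atoms (4 carbon, 1 nitrogen; one five-membered aromatic ring with 1 hetero atom), on a double-bonded chain carbon bound to a double-bonded ring carbon. Because the step of a number 5.3 percentage points lower from compound 1 to compound 2 (within the scatter) at this same place stayed within the scatter, a comparably small outcome is expected here, with no direction favoured. Compound 3 is therefore estimated to give 22%, within a range from 8% to 40%, so that the expected step of a number 3.7 percentage points higher from compound 2 to compound 3 (within the scatter) would remain within the scatter.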

Compound 3, a percentage reported as inhibition, at one concentration (the size of the read-out at that concentration, not a potency): 18.2%
Beside the measured number, compound 3's estimate is 3.8 percentage points above it; the range from low to high includes it.
By their numbers in this assay, from the lowest: compounds 3, 2 and 1 (each within the scatter of the next).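

In this assay, the group of 9 heavy atoms, which brings a six-membered aromatic ring with 1 hetero atom and a hydrogen-bond acceptor that 1H-pyrrol-2-yl lacks, gives a number 0.1 percentage points lower from compound 2 to compound 3 (within the scatter), and set against phenyl it gives a number 5.4 percentage points lower from compound 1 to compound 3 (within the scatter). Within the data shown here, the place on a double-bonded chain carbon bound to a double-bonded ring carbon has thus carried a fused two-ring group as well as two single-ring groups, and no step among the three compounds rises beyond the scatter. No available evidence bears on why these numbers stay so close.

From the compounds shown here alone, it remains open whether an amine or a carboxylic acid on this aromatic group would give a step beyond the scatter. A longer chain in its place is equally untested in the compounds shown, and the same holds for any concentration other than the one reported.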